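Acetyl Replaced by Dimethylamino: Cytotoxicity at a Low Dose

The compounds below may be only part of what the source reports. "The series", "measured", "known", "first", "only" and "open" are said of these compounds alone.

Measured compounds:
compound 1, `COc1cc(C)cc(-c2c(-c3ccnc(-c4ccc(C(C)=O)cc4)c3)cnn2CC#N)c1`, 98%
compound 2, `COc1cc(C)cc(-c2nn(CC#N)cc2-c2ccc(-c3cccc(C(C)=O)c3)nc2)c1`, 98%

In a functional assay on SF-295 cells (Homo sapiens) for cytotoxicity, read by sulforhodamine B assay, with a stated time of 48 h, tested at 0.01 uM (a higher number here means a weaker effect of the compound at the concentration tested, a lower number a stronger effect), compound 1 gives 98%. Compound 2 gives 98% in this assay, and the two compounds stand level within the scatter, so nothing separates them on the numbers shown. Going by the values given here, no pair of measured compounds differs in a single place, so no measured step is available to guide the next comparison.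

Compound 3, `COc1cc(C)cc(-c2c(-c3ccnc(-c4ccc(N(C)C)cc4)c3)cnn2CC#N)c1`, has not yet been measured. It differs from compound 1 by dimethylamino in place of acetyl on an aromatic carbon

Both measured readings lie close to the top of the scale, and compound 1 gives 98%, which leaves little room for a weaker reading. The step from compound 1 to compound 3 is therefore expected to be small, a number 3 percentage points lower from compound 1 to compound 3 (within the scatter), with no change beyond the scatter and, if anything, a slightly lower figure. On that basis compound 3 is estimated at 95% in this assay, with a range from 80% to 105%.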

Compound 3, a percentage reported as activity, at one concentration (the size of the read-out at that concentration, not a potency): 56%
Beside the measured number, compound 3's estimate is 39 percentage points above it, outside the stated range (below it).
By their numbers in this assay, from the lowest: compound 3; then compounds 1 and 2 (each within the scatter of the next).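

Putting dimethylamino in place of acetyl, on an aromatic carbon of a six-membered aromatic ring of carbon only and para to a large group, gives a step of a number 42 percentage points lower from compound 1 to compound 3 (beyond the scatter) in this assay, so the compound with dimethylamino has the stronger effect at this single concentration. Going by these compounds alone, compounds 1 and 2 offered no step to read, and this pair is the first to show that the read-out responds to what sits at this position, even though the two groups match in heavy-atom count, with no ring, no net charge, no hydrogen-bond donors and one hydrogen-bond acceptor each. Nothing available explains why this exchange has so large an effect.

The shown compounds leave open whether the gain belongs to the amine nitrogen itself or to the loss of the acetyl carbonyl, which a primary amine, a methoxy group or a morpholine ring at the same place could help to separate. On these data alone, it also remains open whether the same exchange would carry over to compound 2, and whether the stronger effect seen at this one concentration would hold at other concentrations.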